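Aryl ether at the bicyclic core: cytotoxicity readout

A few compounds are considered here, and "the series" means these few. Any claim that something is new, unique, unknown or untested is made for them only; others in the source may bear on it.

Measured compounds:
compound 1 `COc1ccc(F)cc1CNCCCNc1ccnc2cc(Cc3ccc(F)cc3)ccc12`, 3530 nM
compound 2 `COc1ccc(F)cc1CNCCCNc1ccnc2cc(Cc3ccccc3)ccc12`, 7990 nM
compound 3 `COc1ccc(F)cc1CNCCCNc1ccnc2cc(-c3cccc4ccccc34)ccc12`, 16000 nM

In an ADME assay on HepG2 cells (Homo sapiens) for cytotoxicity, read by luminescence, CellTiter-Glo and ATP content, with a stated time of 72 h (on this read-out higher numbers stand for an effect only at larger amounts of compound and lower numbers for an effect already at smaller amounts), compound 3 gives the highest of the three numbers; the gap to compound 2 is within the scatter, the gap to compound 1 is beyond it, as a 4.5-fold higher number from compound 1 to compound 3 (0.66 log units; beyond the scatter) and a 2.0-fold higher number from compound 2 to compound 3 (0.30 log units; within the scatter) show. Compound 4 `COc1ccc(F)cc1CNCCCNc1ccnc2cc(Oc3ccc(Cl)cc3)ccc12` has not been measured in this assay. It differs from compound 3 in one place: 4-chlorophenoxy in place of naphthalen-1-yl on an aromatic carbon.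

Among the compounds with values here, two measured steps bear on this position. Both replaced a group with one six-membered aromatic ring of carbon only by naphthalen-1-yl and gave a higher number, one beyond the scatter and one within it. Compound 4 returns to a group with one six-membered aromatic ring of carbon only, now carrying an oxygen and a chlorine, so the number is expected to move back toward those of compound 1 and compound 2, by a step of about a 2.7-fold lower number from compound 3 to compound 4 (0.43 log units; beyond the scatter). Compound 4 is therefore estimated at 6000 nM, in a range from 2500 nM to 15000 nM.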

Compound 4, half-maximal effective concentration: 4500 nM
The estimate for compound 4 lay 1.3-fold (0.12 log units) above the measured number, and the stated range covers the measured number.
By their numbers in this assay, from the lowest: compounds 1, 4, 2 and 3 (each within the scatter of the next, the first and the last beyond it).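

In this assay, the single-ring 4-chlorophenoxy group separates from naphthalen-1-yl beyond the scatter, giving a 3.6-fold lower number from compound 3 to compound 4 (0.55 log units; beyond the scatter), so a return to one aromatic ring with an oxygen and a chlorine stays clear of the top of this small set. Against the benzyl groups the change cannot be resolved, with a 1.8-fold lower number from compound 2 to compound 4 (0.25 log units; within the scatter) and a 1.3-fold higher number from compound 1 to compound 4 (0.11 log units; within the scatter), both within the scatter, even though compound 1 and compound 2 lie beyond the scatter of each other. No available evidence bears on the origin of these steps.

On these data alone, the separate contributions of the oxygen and the chlorine remain open, and unsubstituted phenoxy and 4-chlorobenzyl would be the groups to separate them. Also open, as far as these compounds go, is how a morpholine or a carboxylic acid at this position would read out.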